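A few compounds are considered here, and "the series" means these few. Any claim that something is new, unique, unknown or untested is made for them only; others in the source may bear on it.

Compound 1 `O=C(O)CCc1ccc(C#Cc2ccnc(-c3ccccc3)c2)cc1` carries a phenyl on the pyridine side of its core. In an in vitro functional assay on 1321-N1 cells for agonist activity at Free fatty acid receptor 1 (Homo sapiens), read by fluorescence, spectrophotometry and calcium flux (a lower number here means that less compound is needed, a higher number that more compound is needed for the effect), compound 1 gives 186 nM, the higher of the two numbers recorded so far. Compound 2 `O=C(O)CCc1ccc(C#Cc2cc(Cl)nc(Cl)c2)cc1`, in which two chloro groups stand on the same ring, gives in this assay 40.7 nM, a number that lies beyond the usual scatter from that of compound 1. Compound 3 `Cc1cc(C#Cc2ccc(CCC(=O)O)cc2)ccn1` is the next compound, and it differs from compound 1 in one place: methyl in place of phenyl on an aromatic carbon. Within the data shown here, no measured pair shows this particular exchange, so the size of the step has to be judged from the two numbers above alone. From compound 1 to compound 3 the change is expected to be small, a 1.2-fold lower number from compound 1 to compound 3 (0.09 log units; within the scatter), with no clear direction beyond the scatter. Compound 3 is therefore estimated to give about 150 nM in this assay, within a range from 50 nM to 450 nM.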

Compound 3, half-maximal effective concentration: 1120 nM
For compound 3 the middle estimate is 7.5-fold (0.87 log units) below the measured one; measured number above the stated range.
By their numbers in this assay, from the lowest: compound 2; then compound 1; then compound 3.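

In this assay, the exchange of phenyl for methyl next to the ring nitrogen is not a neutral one: it brings a 6.0-fold higher number from compound 1 to compound 3 (0.78 log units; beyond the scatter), so the number at this position responds to the group placed there. In this one pair, the lower number goes with the phenyl, which brings a six-membered aromatic ring of carbon only, and the higher number with the single carbon of the methyl. Nothing among the data shown accounts for this step.

The compounds shown leave open how an ethyl, a methoxy or an amine at this same place would compare with phenyl and methyl. They also leave open whether a substituted phenyl would keep the number of compound 1 186 nM or shift it.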